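Open-chain amide analogues of a trifluoromethylphenyl series

The compounds below may be only part of what the source reports. "The series", "measured", "known", "first", "only" and "open" are said of these compounds alone.

The set pairs two ring compounds with two open-chain ones. Compound 1 `CN1C(=O)CCC1(O)c1cccc(C(F)(F)F)c1` is a ring compound bearing a methyl on the amide-type nitrogen; compound 2 `CCN1C(=O)CCC1(O)c1cccc(C(F)(F)F)c1` carries an ethyl there instead. Compound 3 `CC(C)NC(=O)CCC(=O)c1cccc(C(F)(F)F)c1` opens the ring to a ketone and an isopropyl amide, and compound 4 `CCC(C)NC(=O)CCC(=O)c1cccc(C(F)(F)F)c1` lengthens the isopropyl to a sec-butyl. The difference between the core of compound 1 and the core of compound 3 is not broken down here.

In a functional assay on the whole organism with Mus musculus as the target (a lower number here means that less compound is needed, a higher number that more compound is needed for the effect), compound 1 gives 129 mg/kg. Compound 2 reaches only a limit of the assay in this assay, > 100 mg/kg. Compound 3 likewise reaches only a limit in this assay, > 200 mg/kg. The step from compound 1 to compound 2, (methyl in place of hydrogen on a saturated chain carbon bound to an amide-type nitrogen in a ring), is therefore a step that the limit leaves unreadable from compound 1 to compound 2, as the limit of > 100 mg/kg in this assay, at which 1 of the 3 values shown sits, leaves it unreadable.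

The change from compound 3 to compound 4 is methyl in place of hydrogen on a saturated chain carbon, two bonds along the chain from an amide-type nitrogen. Among the compounds with values here, it is the same kind of change as the one from compound 1 to compound 2, but the place differs: in the ring compounds the methyl enters on a saturated chain carbon bound to an amide-type nitrogen in a ring, whereas in compound 4 it enters two bonds along the chain from an amide-type nitrogen. With the limit of > 200 mg/kg in this assay, at which 1 of the 3 values shown sits, being all that is known for compound 3, and the earlier step being unreadable, the step from compound 3 to compound 4 in this assay is expected to be small, a step that the limit leaves unreadable from compound 3 to compound 4. Compound 4 is therefore estimated at 250 mg/kg, between 100 mg/kg and 600 mg/kg, most likely again only as a limit.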

Compound 4, dose for half-maximal effect: > 200 mg/kg
Compound 4 gave a limit, no number; the forecaster's own chance of this, stated with the estimate: 70%; the middle value is on the limit's open side.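

In this assay, compound 3 and compound 4 both give only a limit of the assay and no number, so no step can be read between them: the limit of > 200 mg/kg in this assay, at which 2 of the 4 values shown sit.

The compounds shown leave open whether methyl in place of hydrogen, two bonds along the chain from an amide-type nitrogen, changes the dose needed for half-maximal effect at all, and in which direction.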